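Amide aryl substituent in a pyrazolyl-pyridine anilide series

The compounds below may be only part of what the source reports. "The series", "measured", "known", "first", "only" and "open" are said of these compounds alone.

Measured so far, in a functional assay on K562 cells (Homo sapiens) for inhibition, read by MTT assay, with a stated time of 48 h; on this read-out lower numbers stand for stronger inhibition and higher numbers for weaker inhibition:
- compound 1 `Cc1ccc(NC(=O)c2ccc(C(F)(F)F)cc2)cc1-n1cc(-c2cccnc2)cn1`: 760 nM
- compound 2 `COc1ccc(C(=O)Nc2ccc(C)c(-n3cc(-c4cccnc4)cn3)c2)cc1`: 18300 nM

Compound 2 stands at the highest number of the two; its nearest neighbour is compound 1, and the step from one to the other, a 24-fold higher number from compound 1 to compound 2 (1.38 log units; beyond the scatter), came with methoxy in place of trifluoromethyl on the amide aryl ring. That single step is the only one measured here, and it shows the substituent at this place can move the read-out by a large amount.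

Compound 3 `Cc1ccc(NC(=O)c2ccc(CN3CCN(C)CC3)cc2)cc1-n1cc(-c2cccnc2)cn1` is the next compound to be measured. Its change from compound 2 is (4-methylpiperazin-1-yl)methyl in place of methoxy on an aromatic carbon. Going by the values given here, no measured step involves this group, so the step from compound 1 to compound 2 bears on it only by showing that this place is sensitive; it gives no direction for a larger, ring-bearing group. On that basis compound 3 is expected to come out with a step of about a 4.6-fold lower number from compound 2 to compound 3 (0.66 log units; beyond the scatter) in this assay, the estimate being wide. The expected value for compound 3 is 4000 nM, within a range of 600 nM to 25000 nM.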

Compound 3, half-maximal inhibitory concentration: 1670 nM
Compound 3: the middle estimate sits 2.4-fold (0.38 log units) above what was measured, and the stated range covers the measured number.
By their numbers in this assay, from the lowest: compound 1; then compound 3; then compound 2.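

Notes on the amide aryl position: in this assay, a much larger, ring-bearing group is compatible with a low number here, since (4-methylpiperazin-1-yl)methyl in place of methoxy gives an 11-fold lower number from compound 2 to compound 3 (1.04 log units; beyond the scatter), a large step. Set against trifluoromethyl, the same group gives a 2.2-fold higher number from compound 1 to compound 3 (0.34 log units; beyond the scatter), a modest step, which leaves compound 1 with the lowest number of the three and compound 2 with the highest. Among these three compounds the number does not track group size alone, as the largest group falls between trifluoromethyl and methoxy, and no available evidence accounts for this order.

The compounds shown leave open which part of the new group carries the step, and a morpholin-4-ylmethyl group, a dimethylaminomethyl group or a piperazin-1-ylmethyl group lacking the terminal methyl would begin to separate the ring, its second nitrogen and that methyl. They also leave open whether trifluoromethyl and (4-methylpiperazin-1-yl)methyl carried together on the same aromatic ring would give a number lower than that of either group alone.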